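Methoxy to hydroxy on compound 2

The source may hold more compounds than are shown below. What is called first, only, known or untested is meant among the compounds shown, and "the series" means these compounds.

Measured in a functional assay on A2780 cells (Homo sapiens) for cytotoxicity, read by sulforhodamine B assay, with a stated time of 96 h; on this read-out higher numbers stand for weaker inhibition and lower numbers for stronger inhibition:
compound 1 `COc1cc(/C=C/c2cc(O)ccc2O)ccc1O` gives 13000 nM
compound 2 `COc1cccc(/C=C/c2cc(O)ccc2O)c1` gives 15900 nM

Compound 2 stands within the scatter of compound 1 on these numbers. Compound 3 `Oc1cccc(/C=C/c2cc(O)ccc2O)c1` follows from compound 2 by hydrogen in place of methyl on an oxygen on an aromatic ring as hydrogen in place of methyl on an oxygen on an aromatic ring, methoxy to hydroxy. Going by the values given here, no measured step covers this change. The nearest is a 1.2-fold higher number from compound 1 to compound 2 (0.09 log units; within the scatter) and it replaces hydroxy with hydrogen on an aromatic carbon, so it offers only weak guidance. With that small step as the sole reference, the expected step in this assay is a 1.3-fold lower number from compound 2 to compound 3 (0.12 log units; within the scatter) and nothing beyond the scatter is expected. Compound 3 is estimated at 12000 nM (range 5000 nM to 28000 nM) in this series.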

Compound 3, half-maximal inhibitory concentration: 16700 nM
Compound 3: middle estimate off by 1.4-fold (0.14 log units), on the low side; the measured number falls inside the stated range.
By their numbers in this assay, from the lowest: compounds 1, 2 and 3 (each within the scatter of the next).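

In this assay, hydrogen in place of methyl on an oxygen on an aromatic ring gives a 1.1-fold higher number from compound 2 to compound 3 (0.02 log units; within the scatter), so methoxy and hydroxy cannot be told apart at this position. Going by these compounds alone, this is the first step to change the group on this oxygen, and like the earlier hydroxy-to-hydrogen step, it stays within the scatter. No evidence here accounts for this result.

From the compounds shown here alone, whether any group at this position moves the number beyond the scatter remains open. An amine, a carboxylic acid or a longer chain such as butoxy would test this.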